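The source may hold more compounds than are shown below. What is called first, only, known or untested is meant among the compounds shown, and "the series" means these compounds.

Measured compounds:
compound 1 `COc1ccc(Br)cc1CCc1c(F)cccc1C(=O)/N=C(\N)NCCN1CCCC1` — a functional assay for antagonist activity at Melanocortin receptor 4 (Homo sapiens), read by cAMP accumulation; a higher number here means a weaker inhibitor, a lower number a stronger inhibitor: 4500 nM
compound 2 `CCCC/N=C(/N)NC(=O)c1cccc(F)c1CCc1cc(Br)ccc1OC` — this assay : "not determined" (no result reported)

Among the measured compounds shown here, compound 1 is the only compound in this set with a number in this assay, where compound 1 gives 4500 nM. For the measured compounds named here, for compound 2 no result was reported in this assay, so nothing can be said about how it compares with compound 1, and no step between measured compounds exists here.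

Compound 3 `COc1ccc(Br)cc1CCc1c(F)cccc1C(=O)/N=C(\N)NCCCCN1CCCCC1` is not yet measured. It differs from compound 1 in one place: 2-(piperidin-1-yl)ethyl in place of pyrrolidin-1-yl on a saturated chain carbon, two bonds along the chain from an amine nitrogen. Going by the values given here, with no measured pair to show what a change of this kind does, the expected size of the step in this assay rests on compound 1 alone. For compound 3 the expectation is a value close to that of compound 1, with a step from compound 1 to compound 3 of a 1.3-fold lower number from compound 1 to compound 3 (0.11 log units; within the scatter) that would not stand out beyond the usual scatter. Compound 3 is therefore estimated at 3500 nM in this assay, with a range from 800 nM to 15000 nM.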

Compound 3, half-maximal inhibitory concentration: 70 nM
The estimate for compound 3 lay 50-fold (1.70 log units) above the measured number, and the stated range ends above it.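

In this assay, replacing pyrrolidin-1-yl with 2-(piperidin-1-yl)ethyl gives a 64-fold lower number from compound 1 to compound 3 (1.81 log units; beyond the scatter), so the group carried on this saturated chain carbon, two bonds along the chain from an amine nitrogen, can strongly change the reading while the shared core stays the same. The earlier compounds shown here could not show this, since they offered no step between measured values. The change is also a double one, turning (2-(pyrrolidin-1-yl)ethyl)amino into (4-(piperidin-1-yl)butyl)amino and so altering both the chain and the ring, from a five-membered to a six-membered non-aromatic ring, and no measurement available here accounts for the gain.

The compounds shown leave open whether the gain belongs to the longer chain, the larger ring or the two together, a question that a 4-(pyrrolidin-1-yl)butyl group or a 2-(piperidin-1-yl)ethyl group on the same amine nitrogen could help to separate. From the compounds shown here alone, with no number for compound 2, its steps cannot be read, and it also remains unknown how a morpholin-4-yl ring or a still longer chain would read at this position.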